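The source may report more compounds than this note shows. Statements on the series, on what has been measured and on what is new or still open speak of the compounds shown alone.

Working notes on the series. The shared core is that of compound 1 `Nc1nc(OCC(F)(F)F)c2ncn(/C=C3/CC3(CO)CO)c2n1`, and the three measured compounds differ only in the group on one aromatic carbon. In an ADME assay on CCRF-HSB-2 cells (Homo sapiens) for cytotoxicity, with a stated time of 7 days (on this read-out higher numbers stand for lower toxicity in this test and lower numbers for higher toxicity in this test), compound 1 reaches only the limit of the assay, > 20000 nM. Within the data shown here, compound 2 `CC(C)CSc1nc(N)nc2c1ncn2/C=C1/CC1(CO)CO` carries isobutylsulfanyl in place of 2,2,2-trifluoroethoxy on an aromatic carbon, and in this assay compound 2 gives 60000 nM, the only number in the set. Compound 3 `C=CCOc1nc(N)nc2c1ncn2/C=C1/CC1(CO)CO` carries allyloxy on that carbon. In this assay compound 3 also reaches only the limit, > 20000 nM. The step that the limit leaves unreadable from compound 1 to compound 2 is not readable in size, and neither is a step that the limit leaves unreadable from compound 2 to compound 3 or a step that the two limits leave unreadable from compound 1 to compound 3, because of the limit of > 20000 nM in this assay, at which 2 of the 3 values shown sit.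

Compound 4 `CCCNc1nc(N)nc2c1ncn2/C=C1/CC1(CO)CO` is not yet measured. (propylamino in place of isobutylsulfanyl on an aromatic carbon). Both measured steps that touch compound 2 are unreadable, so they give no direction for the change; none of the three measured compounds shows a value on the toxic side of the set. Compound 4 is therefore expected to show a step of a 1.5-fold lower number from compound 2 to compound 4 (0.18 log units; within the scatter), within the scatter. Compound 4 is estimated in this assay at 40000 nM, with a range of 12000 nM to 150000 nM, and a limit rather than a number is a real possibility.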

Compound 4, half-maximal cytotoxic concentration: > 20000 nM
Compound 4 gave a limit, no number; the forecaster's own chance of this, stated with the estimate: 55%; the middle value is on the limit's open side.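

In this assay compound 4 gives > 20000 nM as a limit and not a number. Its steps to compound 1, compound 2 and compound 3 therefore cannot be read in size, because of this limit: the limit of > 20000 nM in this assay, at which 3 of the 4 values shown sit. The compounds shown leave open whether the group on that aromatic carbon changes this read-out at all.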